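Series notes: aryl substituent replaced by hydrogen

A few compounds are considered here, and "the series" means these few. Any claim that something is new, unique, unknown or untested is made for them only; others in the source may bear on it.

compound 1 `CS(=O)(=O)Nc1cccc2c1CCC2c1ncc[nH]1` — 70 nM
compound 2 `c1cc(-c2nccs2)c2c(c1)C(c1ncc[nH]1)CC2` — 426 nM
compound 3 `Cc1oncc1-c1cccc2c1CCC2c1ncc[nH]1` — 111 nM

Of the compounds shown here, three share the core of compound 1 and have been measured in a functional assay on CHO cells for agonist activity at Alpha-1A adrenergic receptor (Homo sapiens), read by FLIPR and calcium flux; a lower number here means that less compound is needed, a higher number that more compound is needed for the effect. Compound 3 stands second highest of the three numbers. Its nearest neighbour is compound 1, with a 1.6-fold higher number from compound 1 to compound 3 (0.20 log units; within the scatter); its furthest is compound 2, with a 3.8-fold lower number from compound 2 to compound 3 (0.58 log units; beyond the scatter). The whole substituted set spans a 6.1-fold higher number from compound 1 to compound 2 (0.78 log units; beyond the scatter).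

Compound 4 `c1ccc2c(c1)CCC2c1ncc[nH]1` is the unsubstituted core. It differs from compound 3 by hydrogen in place of 5-methyl-1,2-oxazol-4-yl on an aromatic carbon.

Among the compounds with values here, none of the measured steps bears directly on this change: each of them exchanges one group for another group at that same aromatic carbon, and none removes the group altogether. What they do show is that swapping among three quite different groups moves this assay by no more than the span from compound 1 to compound 2, a modest amount. Removal to hydrogen is a larger structural loss than any of those swaps, so a step beyond the scatter toward a higher number seems more likely than not, but the direction is not fixed by the data. Compound 4 is therefore expected to show a 2.7-fold higher number from compound 3 to compound 4 (0.43 log units; beyond the scatter), with its value estimated at 300 nM and a wide range from 90 nM to 1000 nM.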

Compound 4, half-maximal effective concentration: 473 nM
For compound 4 the middle estimate is 1.6-fold (0.20 log units) below the measured one, and the stated range covers the measured number.
By their numbers in this assay, from the lowest: compounds 1 and 3 (each within the scatter of the next); then compounds 2 and 4 (each within the scatter of the next).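

In this assay, within the data shown here, the removal of the group gives the first direct reading of what a substituent on this aromatic carbon is worth: with hydrogen in place of 5-methyl-1,2-oxazol-4-yl there is a 4.3-fold higher number from compound 3 to compound 4 (0.63 log units; beyond the scatter) and with hydrogen in place of methanesulfonamido there is a 6.8-fold higher number from compound 1 to compound 4 (0.83 log units; beyond the scatter) so both of these groups go with a lower number than the bare core. 1,3-Thiazol-2-yl does not follow this pattern: a 1.1-fold higher number from compound 2 to compound 4 (0.05 log units; within the scatter) leaves that group and hydrogen inseparable here, so carrying a five-membered aromatic ring at this place does not by itself bring the lower number, as compound 3 and compound 2 differ on that point. Nothing available explains why compound 2 parts from compound 1 and compound 3 in this way.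

On these data alone, it remains open whether an amine, a carboxylic acid or a simple methyl or methoxy group on this aromatic carbon would fall with compound 1 and compound 3 or with compound 2 and compound 4. It also remains open whether the same removal would read alike at another carbon of the six-membered aromatic ring, as every group shown here sits at one place.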